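This account rests on a few compounds, and the source may have more. Where it says the series, first, only, none or still open, it means among the compounds named here.

Measured so far:
compound 1, `CC(C)C(c1ccc(-c2ccc3cccc(F)c3c2)[nH]c1=O)C1SC(=O)NC1=O`, 26.3 10^-6 cm/s
compound 2, `CC(C)C(/C=C1\SC(=O)NC1=O)c1ccc(-c2ccc3cccc(F)c3c2)[nH]c1=O`, 15.4 10^-6 cm/s

In an ADME assay on MDCK cells (Canis lupus familiaris) for permeability, in the apical to basolateral direction (a higher number here means that the compound crosses the layer faster, a lower number that the compound crosses the layer more slowly), compound 2 holds the lowest of the two numbers; its nearest neighbour is compound 1, and the gap is a 1.7-fold lower number from compound 1 to compound 2 (0.23 log units; within the scatter). Compound 3, `CC(C)C(/C=C1/C(=O)NC(=O)N1C)c1ccc(-c2ccc3cccc(F)c3c2)[nH]c1=O`, brings (a group of 9 heavy atoms (5 carbon, 2 nitrogen, 2 oxygen; one five-membered non-aromatic ring with 2 hetero atoms) in place of a group of 8 heavy atoms (4 carbon, 1 nitrogen, 2 oxygen, 1 sulfur; one five-membered non-aromatic ring with 2 hetero atoms), on a saturated chain carbon bound to an aromatic carbon and a saturated chain carbon). Among the measured compounds shown here, the only measured step, a 1.7-fold lower number from compound 1 to compound 2 (0.23 log units; within the scatter), reshapes the same part of the molecule but in a different way and stays within the scatter, so it offers little guidance here. No step beyond the scatter is expected. Compound 3 is estimated at 12 10^-6 cm/s, with a range from 5 10^-6 cm/s to 25 10^-6 cm/s. This estimate means an expected 1.3-fold lower number from compound 2 to compound 3 (0.11 log units; within the scatter).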

Compound 3, apparent permeability: 14.1 10^-6 cm/s
For compound 3 the middle estimate is 1.2-fold (0.07 log units) below the measured one; the range from low to high includes it.
By their numbers in this assay, from the lowest: compounds 3, 2 and 1 (each within the scatter of the next).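

In this assay, replacing the sulfur-containing five-membered ring with the one carrying two nitrogens and no sulfur gives a 1.1-fold lower number from compound 2 to compound 3 (0.04 log units; within the scatter) and, against the first compound, a 1.9-fold lower number from compound 1 to compound 3 (0.27 log units; within the scatter). On this saturated chain carbon, all three ring groups therefore give numbers within the scatter of one another, even though the sulfur has gone. Nothing measured here offers a reason for this. Still open, as far as these compounds go, is whether a group of a different kind in this place, such as a carboxylic acid or an amine, would move the number beyond the scatter.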